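Replacing the fluoropyridinyl oxime ether with a fluoroethoxyethyl chain

This account rests on a few compounds, and the source may have more. Where it says the series, first, only, none or still open, it means among the compounds named here.

The measured compounds and their numbers are:
compound 1 `Cc1cccc(C#CC2=C/C(=N/Oc3cccc(F)n3)CCC2)n1`, 46.8 nM;
compound 2 `Fc1cccc(O/N=C2/C=C(C#Cc3ccccn3)CCC2)n1`, 9.15 nM;
compound 3 `N#Cc1ccc(O/N=C2\C=C(C#Cc3ccccn3)CCC2)cc1F`, 49.8 nM.

In an assay on brain (strain Sprague-Dawley) for displacement of a labelled ligand from metabotropic glutamate receptor 5 (Rattus norvegicus), with a stated time of 45 min (a higher number here means a weaker inhibitor, a lower number a stronger inhibitor), compound 1 gives 46.8 nM, which is the second highest of the three numbers; its nearest neighbour is compound 3 with 49.8 nM, a gap within the scatter, while compound 2 with 9.15 nM lies furthest away. Within the data shown here, the one step among the measured compounds that differs in a single place is a 5.1-fold lower number from compound 1 to compound 2 (0.71 log units; beyond the scatter).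

Compound 4 `Cc1cccc(C#CC2=C/C(=N/OCCOCCF)CCC2)n1` is not yet measured. It differs from compound 1 in this way: 2-(2-fluoroethoxy)ethyl in place of 6-fluoropyridin-2-yl on an oxygen. Among the measured compounds shown here, none of the measured steps touches this part of the molecule; the step from compound 1 to compound 2 concerns a methyl on the aromatic ring, and compounds 2 and 3 differ in their oxime-ether aryl group in more than one place, so they give only a rough sense of how much that region matters. For the measured compounds named here, with no direct precedent, the change from an aromatic to an open-chain group on the oxime oxygen is expected to cost some potency, and compound 4 is expected to come in at 150 nM, within 40 nM to 600 nM. This means an expected step of a 3.2-fold higher number from compound 1 to compound 4 (0.51 log units; beyond the scatter).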

Compound 4, inhibition constant: 26.8 nM
Compound 4: middle estimate off by 5.6-fold (0.75 log units), on the high side, and the stated range ends above it.
By their numbers in this assay, from the lowest: compound 2; then compounds 4, 1 and 3 (each within the scatter of the next).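

In this assay, putting 2-(2-fluoroethoxy)ethyl in place of 6-fluoropyridin-2-yl on the oxygen bound to the double-bonded nitrogen gives a 1.7-fold lower number from compound 1 to compound 4 (0.24 log units; within the scatter). All three earlier compounds carry an aromatic ring on this oxygen, so they could not show what this pair shows: in the core of compound 1, an open chain with no ring can take the place of that ring with no change in the number beyond the scatter. The data give no explanation for this tolerance of so different a group.

On these data alone, it remains open whether the chain behaves the same way on the other side of the molecule, where removing the methyl from the aromatic carbon gave a 5.1-fold lower number from compound 1 to compound 2 (0.71 log units; beyond the scatter), so that the effect of that change on a compound carrying the chain cannot be told from this pair. Also open, as far as these compounds go, is how far this tolerance extends, for instance to a longer chain with a further ethoxy unit, to a plain ethyl group, or to a chain ending in an amine or a carboxylic acid in place of the fluorine.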